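The source may hold more compounds than are shown below. What is called first, only, known or untested is meant among the compounds shown, and "the series" means these compounds.

Compound 2 `O=C(O)CCN1Cc2ccc(NC(=O)c3cccc(N4CCNCC4)c3)cc2C1=O` is one of two compounds that have been measured so far. In a functional assay on a cell-free system (Platelet, plasma, Homo sapiens) for inhibition (a lower number here means a stronger inhibitor, a higher number a weaker inhibitor), compound 2 gives 2700 nM. The other measured compound, compound 1 `O=C(O)CCCN1Cc2ccc(NC(=O)CC3CCNCC3)cc2C1=O`, gives 1800 nM in this assay, a number that lies within the scatter of the result for compound 2, so the two cannot be ranked against each other. Compound 3 `CC(CC(=O)O)N1Cc2ccc(NC(=O)c3cccc(N4CCNCC4)c3)cc2C1=O` has not yet been measured. It differs from compound 2 in a single place: methyl in place of hydrogen on a saturated chain carbon bound to an amide-type nitrogen in a ring and a saturated chain carbon. Read one bond further out, the change turns 2-carboxyethyl into 1-(carboxymethyl)ethyl. Among the measured compounds shown here, no measured pair shows what a change of this kind does in this assay, and nothing among the measured compounds points in either direction. The estimated step is therefore small, no change at the digits printed from compound 2 to compound 3 (within the scatter), and expected to stay within the scatter. Compound 3 is expected to give about 2700 nM in this assay, with a likely range from 900 nM to 8000 nM.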

Compound 3, half-maximal inhibitory concentration: 62000 nM
The estimate for compound 3 lay 23-fold (1.36 log units) below the measured number; measured number above the stated range.
By their numbers in this assay, from the lowest: compounds 1 and 2 (each within the scatter of the next); then compound 3.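

In this assay, placing methyl in place of hydrogen on the saturated chain carbon bound to the ring's amide-type nitrogen, which turns 2-carboxyethyl into 1-(carboxymethyl)ethyl, gives a 23-fold higher number from compound 2 to compound 3 (1.36 log units; beyond the scatter). This position is therefore sensitive: one added carbon, with no ring, no net charge and no hydrogen-bond donors or acceptors, weakens inhibition well beyond the scatter, whereas compound 1 and compound 2 differ in more than one place and could not show this. Nothing in the data given explains the loss.

The compounds shown leave open whether a larger ethyl group or a hydroxyl group on this same carbon would have a similar effect. They also leave open whether the same methyl would cost as much on the longer acid-bearing chain of compound 1.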